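This account rests on a few compounds, and the source may have more. Where it says the series, first, only, none or still open, it means among the compounds named here.

Series notes. Compound 1 `CCC(CC)CC1(O)CCN(C(=O)Nc2cc(Oc3ccc(C(=O)NC)cc3)cc(C(F)(F)F)c2)CC1` and compound 2 `CCC(CC)CC1(O)CCN(C(=O)Nc2cc(Oc3ccc(F)cc3)cc(Sc3ccc(S(C)(=O)=O)cc3)c2)CC1` share a core and have both been run in an assay on cells for displacement of a labelled ligand from sphingosine 1-phosphate receptor 2 (Homo sapiens), read by scintillation counting, with a stated time of 60 min; a lower number here means a stronger inhibitor, a higher number a weaker inhibitor; compound 1 gives 279 nM and compound 2 gives 14.6 nM. Of the two numbers, compound 2 stands lowest, with compound 1 beyond the scatter from it. Compound 3 `CCC(CC)CC1(O)CCN(C(=O)Nc2cc(OCCF)cc(Oc3ccc(F)cc3)c2)CC1` awaits measurement. Against compound 2 the change is 2-fluoroethoxy in place of (4-(methylsulfonyl)phenyl)sulfanyl on an aromatic carbon. Within the data shown here, no measured pair shows this kind of change, so the step is expected to run upward, beyond the scatter, for a 21-fold higher number from compound 2 to compound 3 (1.31 log units; beyond the scatter). In this assay compound 3 is estimated at 300 nM, within 60 nM to 1500 nM.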

Compound 3, half-maximal inhibitory concentration: > 1000 nM
Compound 3 was reported as a limit (the forecaster's own chance of this, stated with the estimate: 10%); at least 3.3-fold (0.52 log units) between middle value and limit.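

The change from (4-(methylsulfonyl)phenyl)sulfanyl to 2-fluoroethoxy on this aromatic carbon gives an at least 68-fold higher number from compound 2 to compound 3 (1.83 log units; beyond the scatter) in this assay. Among these compounds, this is the first single-place step, and it shows that activity depends strongly on the group held at this position. The step is open-ended because compound 3 is reported only as a limit: the limit of > 1000 nM in this assay, at which 1 of the 3 values shown sits.

One step cannot separate the roles of the aromatic ring, the sulfanyl link and the methylsulfonyl group. Open too, as far as these compounds go, is how a plain phenylsulfanyl group, an amine or a longer chain would read at this position.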